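Swapping the distal aryl group: chlorines out, nitrile in

This account rests on a few compounds, and the source may have more. Where it says the series, first, only, none or still open, it means among the compounds named here.

The study examines three compounds that share a core and differ only in the aryl group that sits on an oxygen on an aromatic ring. Compound 1 `Cc1cccc(Oc2cccc(COc3ccccc3CCC(=O)OCCCOP(=O)(O)OC[C@H](N)C(=O)O)c2)c1` carries a 3-methylphenyl there, and in an assay on cells for activation of probable G-protein coupled receptor 34 (Mus musculus), with a stated time of 1 h (a lower number here means a smaller maximal response, a higher number a larger maximal response), compound 1 gives 0.29. Compound 2 `N[C@@H](COP(=O)(O)OCCCOC(=O)CCc1ccccc1OCc1cccc(Oc2ccc(Cl)c(Cl)c2)c1)C(=O)O` carries a 3,4-dichlorophenyl instead, and in this assay compound 2 gives 0.71, the higher of the two measured numbers; the step a number 0.42 higher from compound 1 to compound 2 (beyond the scatter) lies well beyond the scatter. Compound 3 `N#Cc1ccc(Oc2cccc(COc3ccccc3CCC(=O)OCCCOP(=O)(O)OC[C@H](N)C(=O)O)c2)cc1` is the unmeasured member, and it differs from compound 2 in 4-cyanophenyl in place of 3,4-dichlorophenyl on an oxygen on an aromatic ring.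

For the measured compounds named here, only one measured step bears on this change, and it shows that exchanging the aryl group at this position can move the maximal response a great deal. Going by the values given here, no measured pair contains a 4-cyanophenyl, so the direction for compound 3 is uncertain. Among the compounds with values here, because the single step a number 0.42 higher from compound 1 to compound 2 (beyond the scatter) was large, the estimate for compound 3 is given a wide range: the step is expected to be a number 0.21 lower from compound 2 to compound 3 (beyond the scatter). The maximal response of compound 3 in this assay is expected to be 0.5, within 0.25 to 0.8.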

Compound 3, intrinsic activity: the largest response reached, as a fraction of the reference agonist's: 0.041
The estimate for compound 3 lay 0.46 above the measured number; measured number below the stated range.
By their numbers in this assay, from the lowest: compound 3; then compound 1; then compound 2.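

Replacing the 3,4-dichlorophenyl with a 4-cyanophenyl gives a number 0.67 lower from compound 2 to compound 3 (beyond the scatter) in this assay, so the earlier gain in maximal response is more than lost at this position. The comparison with the 3-methylphenyl compound gives a number 0.25 lower from compound 1 to compound 3 (beyond the scatter) and places compound 3 at the bottom of the three, showing that an aryl exchange here can lower the response as well as raise it, and that the 3-methylphenyl does not mark the lower end of the range. The 3,4-dichlorophenyl and the 4-cyanophenyl have the same number of heavy atoms and each holds one six-membered aromatic ring of carbon only, so a large difference in maximal response arises here without any change in either count.

The three compounds leave open whether the fall tracks the arrival of the nitrile or the departure of the chlorines, a question that a 4-chlorophenyl or an unsubstituted phenyl at this position would help to separate. No measurement shown here explains why the three aryl groups differ in this way.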